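A Bulkier Branched Chain on the Double-Bonded Nitrogen

This account rests on a few compounds, and the source may have more. Where it says the series, first, only, none or still open, it means among the compounds named here.

Among the measured compounds shown here, compound 2, `CC(C)CC/N=C(\NC#N)Nc1cc(C(F)(F)F)cc(C(F)(F)F)c1`, is the only compound here with a measured number. In a functional assay (aorta) with Rattus norvegicus as the target (on this read-out lower numbers stand for stronger inhibition and higher numbers for weaker inhibition), compound 2 gives 5600 nM. Compound 1, `N#CN/C(=N\C1CCCC1)Nc1cc(C(F)(F)F)cc(C(F)(F)F)c1`, differs from it only in the group on the double-bonded nitrogen. In this assay compound 1 gives > 300000 nM, which is a limit of the assay and not a number (the limit of > 300000 nM in this assay, at which 1 of the 2 values shown sits). For the measured compounds named here, the single measured step is therefore an at least 53-fold lower number from compound 1 to compound 2 (1.72 log units; beyond the scatter), and it shows that the group on this nitrogen can move the read-out greatly.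

Compound 3, `C[C@H](/N=C(\NC#N)Nc1cc(C(F)(F)F)cc(C(F)(F)F)c1)C(C)(C)C`, changes the same position again: 1,2,2-trimethylpropyl in place of isopentyl on a double-bonded nitrogen. The measured step swapped a ring for a chain, whereas here one chain replaces another, slightly longer and more branched, so it bears only loosely on the new change. A modest step is expected, plausibly within the scatter, and the expected step is a 1.4-fold lower number from compound 2 to compound 3 (0.15 log units; within the scatter). Compound 3 is estimated to give 4000 nM in this assay, with a range from 1000 nM to 20000 nM.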

Compound 3, half-maximal inhibitory concentration: 11900 nM
Beside the measured number, compound 3's estimate is 3.0-fold (0.47 log units) below it; low and high end bracket the measured number.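

Swapping cyclopentyl for a second open chain, 1,2,2-trimethylpropyl, also produces a large step, an at least 25-fold lower number from compound 1 to compound 3 (1.40 log units; beyond the scatter), so a measurable read-out at this position is not confined to isopentyl. The two chains are not interchangeable, however: putting 1,2,2-trimethylpropyl, with its defined stereocentre, in place of isopentyl gives a 2.1-fold higher number from compound 2 to compound 3 (0.33 log units; beyond the scatter), a modest step that is beyond the usual scatter, so in this pair the more branched chain goes with weaker inhibition. The step from the ring-bearing compound rests on a value for compound 1 that is a limit of the assay and not a number: the limit of > 300000 nM in this assay, at which 1 of the 3 values shown sits.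

In compound 3, the branching and the stereocentre enter together, so the share of each in the step cannot be read, and the mirror-image form of 1,2,2-trimethylpropyl would be needed to isolate the stereocentre. The compounds shown also leave open how a straight pentyl chain, a shorter ethyl chain or a larger cyclohexyl ring on the double-bonded nitrogen would compare with these three groups.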